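Compound 3 to compound 4: cytotoxicity at the assay limit

The source may report more compounds than this note shows. Statements on the series, on what has been measured and on what is new or still open speak of the compounds shown alone.

In an ADME assay on cells (Fibroblast, Gallus gallus) for cytotoxicity, read by CCK-8 assay, with a stated time of 48 h (a lower number here means that less compound is tolerated, a higher number that more compound is tolerated), compound 3 (`CCC(CC)O[C@@H]1C=C(C(=O)O)C[C@H](NCc2cccc(OC)c2)[C@H]1NC(C)=O`) gives > 200000 nM as its result, a limit and not a number. Compound 1 (`CCc1ccc(CN[C@H]2CC(C(=O)O)=C[C@@H](OC(CC)CC)[C@@H]2NC(C)=O)cc1`) gives > 200000 nM as its result, also a limit. Compound 2 (`CCC(CC)O[C@@H]1C=C(C(=O)O)C[C@H](NCc2ccc(C(C)C)cc2)[C@H]1NC(C)=O`) gives > 200000 nM as its result, again a limit.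

Compound 4 (`CCC(CC)O[C@@H]1C=C(C(=O)O)C[C@H](NCc2ccc(OC(C)C)cc2)[C@H]1NC(C)=O`) carries 4-isopropoxyphenyl in place of 3-methoxyphenyl on a saturated chain carbon bound to an amine nitrogen.

Each measured step alters the same aromatic group: a step that the two limits leave unreadable from compound 1 to compound 2 and a step that the two limits leave unreadable from compound 1 to compound 3 and a step that the two limits leave unreadable from compound 2 to compound 3 all bear on the change, and none has a readable size. From compound 3 no step beyond the scatter is expected in this assay, the expectation resting on (the limit of > 200000 nM in this assay, at which 3 of the 3 values shown sit), and no direction can be given. The estimated change is a step that the limit leaves unreadable from compound 3 to compound 4, with the result most likely reported as a limit again. Compound 4 is estimated at 250000 nM, with an expected range of 150000 nM to 500000 nM for a numerical result.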

Compound 4, half-maximal cytotoxic concentration: > 200000 nM
Compound 4: only a limit was reported; the forecaster's own chance of this, stated with the estimate: 85%; the middle value does not contradict the limit.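

In this assay, for the compounds shown here, compound 4 gives > 200000 nM, a limit and not a number; no step among compound 1, compound 2, compound 3 and compound 4 can be read. The compounds shown leave open whether any aromatic group on the shared core gives a numerical result in this assay: the limit of > 200000 nM in this assay, at which 4 of the 4 values shown sit.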